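Seleno-sugar nucleosides: cytotoxicity stays at the limit

This account rests on a few compounds, and the source may have more. Where it says the series, first, only, none or still open, it means among the compounds named here.

Measured so far:
- compound 1, `Cc1cn([C@H]2C[Se][C@@H](CO)O2)c(=O)[nH]c1=O`: in a functional assay on CCRF-CEM cells (Homo sapiens) for cytotoxicity (a higher number here means a weaker inhibitor, a lower number a stronger inhibitor), compound 1 gives > 100000 nM, a limit of the assay.
- compound 2, `Nc1ccn([C@H]2C[Se][C@@H](CO)O2)c(=O)n1`: in this assay compound 2 gives > 100000 nM; 100000 nM; > 100000 nM (3 entries).
- compound 3, `Nc1ncnc2c1ncn2[C@H]1C[Se][C@@H](CO)O1`: in this assay compound 3 gives > 100000 nM, a limit of the assay.

Compound 3 stands only at a limit; no number is known for it. Compound 1 sits at the same kind of limit. For compound 2 the picture is the several entries of compound 2 in this assay, > 100000 nM; 100000 nM; > 100000 nM (3 entries), with two of three values at the limit of > 100000 nM in this assay, at which 2 of the 3 values shown sit. For the measured compounds named here, no pair of measured compounds differs in one place, so no measured step size is available, and nothing separates one compound from another beyond the scatter.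

Compound 4, `OC[C@H]1O[C@@H](n2cnc3c(O)ncnc32)C[Se]1`, differs from compound 3 by hydroxy in place of amino on an aromatic carbon. Going by the values given here, with every base variation so far at the limit, the change is expected to give no step beyond the scatter, most likely another limit. The expected step is a step that the limit leaves unreadable from compound 3 to compound 4. Compound 4 is therefore estimated at 150000 nM in this assay, within 60000 nM to 500000 nM.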

Compound 4, half-maximal inhibitory concentration: > 100000 nM
Compound 4 ended at the assay's limit; the forecaster's own chance of this, stated with the estimate: 90%; the middle value does not contradict the limit.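

In this assay compound 3 and compound 4 both stand at a limit of the assay, so no step can be read between them. Whether any change on the shared core gives a readable number in this assay rather than a limit stays open with the compounds shown.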